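The source may hold more compounds than are shown below. What is called first, only, known or untested is meant among the compounds shown, and "the series" means these compounds.

Compound 1 `CNC(=O)/C=C/CN1CC(Oc2ccc(Oc3c(-c4ccc(F)cc4)sc4cc(O)ccc34)cc2)C1` and compound 2 `C/C=C/C(=O)NCCOc1ccc(Oc2c(-c3ccc(F)cc3)sc3cc(O)ccc23)cc1` share one core and differ only in the chain on the oxygen on the aromatic ring. In a functional assay on MCF7 cells (Homo sapiens) for antiproliferative activity, read by CCK-8 assay, with a stated time of 48 h (a lower number here means a stronger inhibitor, a higher number a weaker inhibitor), compound 1 reaches only the limit of the assay, > 25000 nM, and no number. In this assay compound 2 gives 21700 nM. The step of an at least 1.1-fold lower number from compound 1 to compound 2 (0.06 log units; that floor lies within the scatter) stays within the scatter, with 2-(((prop-1-en-1-yl)carbonyl)amino)ethyl in place of 1-(3-(methylcarbamoyl)prop-2-en-1-yl)azetidin-3-yl. Compound 3 `CN(C)C(=O)/C=C/CN1CC(Oc2ccc(Oc3c(-c4ccc(F)cc4)sc4cc(O)ccc34)cc2)C1` keeps the chain of compound 1 and carries methyl in place of hydrogen on an amide-type nitrogen. Compound 1 sits at the limit of > 25000 nM in this assay, at which 1 of the 2 values shown sits. Among the measured compounds shown here, only the step from compound 1 to compound 2 touches this part of the molecule, and it shows no movement beyond the scatter. For compound 3 a step of a number no higher from compound 1 to compound 3 (the limit leaves the size open) is expected, none beyond the scatter, with a fair chance of another limit. Compound 3 is therefore estimated at 25000 nM, between 10000 nM and 60000 nM.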

Compound 3, half-maximal inhibitory concentration: 22300 nM
Estimate against measurement, compound 3: 1.1-fold (0.05 log units) above, and the stated range covers the measured number.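

Methyl in place of hydrogen on the amide-type nitrogen gives an at least 1.1-fold lower number from compound 1 to compound 3 (0.04 log units; that floor lies within the scatter) in this assay, so this change brings no movement beyond the scatter that can be read. On these data alone, the step has only a floor and its true size stays open, because compound 1 stands at a limit of the assay: the limit of > 25000 nM in this assay, at which 1 of the 3 values shown sits. Exchanging the whole chain on the oxygen gives a 1.0-fold higher number from compound 2 to compound 3 (0.01 log units; within the scatter), so the dimethylcarbamoyl chain and the chain of compound 2 stand level in this assay.

As far as these compounds go, whether a primary amide, a carboxylic acid or a basic amine in place of the dimethylcarbamoyl group, or a longer chain on the oxygen, would move the number beyond the scatter stays open. The compounds shown also leave open whether the chain on the oxygen has any bearing on the read-out in this assay.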